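The compounds below may be only part of what the source reports. "The series", "measured", "known", "first", "only" and "open" are said of these compounds alone.

Measured so far:
compound 1, `COc1ccc(C(=O)Nc2cccc(NC(=O)COc3ccc4c(=O)ccoc4c3)c2)cc1`, 18 nM
compound 2, `O=C(COc1ccc2c(=O)ccoc2c1)Nc1cccc(NC(=O)c2ccc([N+](=O)[O-])cc2)c1`, 67 nM

Both numbers come from an assay on isolated protein for inhibition of Rho-associated protein kinase 1 (Homo sapiens), read by scintillation counting, radiometric assay and 33P incorporation, with a stated time of 40 min, in the presence of a further agent that is not named here; a lower number here means a stronger inhibitor, a higher number a weaker inhibitor. Among the compounds with values here, compound 2 gives the higher of the two values; the only neighbour is compound 1, and the step between them, a 3.7-fold higher number from compound 1 to compound 2 (0.57 log units; beyond the scatter), is a change on the aromatic carbon of the outer benzamide ring only.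

Compound 3, `NCc1ccc(C(=O)Nc2cccc(NC(=O)COc3ccc4c(=O)ccoc4c3)c2)cc1`, is still to be measured in this assay. It differs from compound 2 at the same aromatic carbon: aminomethyl in place of nitro on an aromatic carbon. Within the data shown here, the one measured step that bears on this position shows that exchanging the group there moves the number by a modest but real amount, with methoxy giving the lower value. Among the measured compounds shown here, no measured compound carries aminomethyl, so the direction for compound 3 rests on that single step alone. The expectation is that compound 3 returns to roughly the range of compound 1, a step of a 2.2-fold lower number from compound 2 to compound 3 (0.35 log units; beyond the scatter) being expected. Compound 3 is therefore estimated at 30 nM, with a likely range from 8 nM to 110 nM.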

Compound 3, half-maximal inhibitory concentration: 532 nM
The estimate for compound 3 lay 18-fold (1.25 log units) below the measured number; the whole stated range lies below it.
By their numbers in this assay, from the lowest: compound 1; then compound 2; then compound 3.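

In this assay, the group at this aromatic carbon matters far more than the first pair showed: aminomethyl brings a 7.9-fold higher number from compound 2 to compound 3 (0.90 log units; beyond the scatter) and a 30-fold higher number from compound 1 to compound 3 (1.47 log units; beyond the scatter). The position therefore spreads the series well beyond the step seen with methoxy and nitro, and the order from lowest number to highest is methoxy, nitro, aminomethyl, with each step beyond the scatter. Nothing at hand explains why aminomethyl sits so far from the other two groups.

Going by these compounds, whether the change in the number follows the amine nitrogen or the carbon that links it to the ring remains open, and a directly attached amino group or a hydroxymethyl group would help separate the two. A dimethylaminomethyl group or a carboxylic acid at the same carbon would show how far the trend extends.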